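The source may hold more compounds than are shown below. What is called first, only, known or untested is meant among the compounds shown, and "the series" means these compounds.

For the measured compounds named here, in a functional assay on Shh Light II cells (Mus musculus) for inhibition, read by a luciferase reporter (on this read-out lower numbers stand for stronger inhibition and higher numbers for weaker inhibition), three compounds sharing one core have numbers so far. Compound 1 (`O=C(CC1CCCCCC1)N1CCC(c2nc(-c3ccc4ccccc4n3)no2)CC1`) gives 840 nM, compound 2 (`O=C(NC1CCS(=O)(=O)CC1)N1CCC(c2nc(-c3ccc4ccccc4n3)no2)CC1`) gives 360 nM and compound 3 (`O=C(NC1CCC(O)CC1)N1CCC(c2nc(-c3ccc4ccccc4n3)no2)CC1`) gives 2700 nM, the highest of the three and so the weakest inhibitor of the set. Compound 4 (`O=C(OC1CCCCC1)N1CCC(c2nc(-c3ccc4ccccc4n3)no2)CC1`) differs from compound 3 by cyclohexyloxy in place of (4-hydroxycyclohexyl)amino on a carbonyl carbon. Going by the values given here, no measured step makes this exact exchange, but all three change the group on that same carbonyl carbon. They are modest: a 3.2-fold higher number from compound 1 to compound 3 (0.51 log units; beyond the scatter), a 7.5-fold higher number from compound 2 to compound 3 (0.88 log units; beyond the scatter) and a 2.3-fold lower number from compound 1 to compound 2 (0.37 log units; beyond the scatter). Both steps ending at compound 3 go upward, so a move away from (4-hydroxycyclohexyl)amino has so far lowered the number. Compound 1, which also has no hydroxy group on its ring, is the nearest guide at 840 nM. In this assay the expected result is a 3.4-fold lower number from compound 3 to compound 4 (0.53 log units; beyond the scatter), a modest step to a lower number. The estimate for compound 4 is 800 nM, with an expected range from 250 nM to 2500 nM.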

Compound 4, half-maximal inhibitory concentration: 580 nM
Compound 4: middle estimate off by 1.4-fold (0.14 log units), on the high side, within the range that was stated.
By their numbers in this assay, from the lowest: compounds 2, 4 and 1 (each within the scatter of the next, the first and the last beyond it); then compound 3.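

In this assay, for the compounds shown here, compound 4 is the first compound with an oxygen joining its ring to the carbonyl carbon, and cyclohexyloxy in place of (4-hydroxycyclohexyl)amino gives a 4.7-fold lower number from compound 3 to compound 4 (0.67 log units; beyond the scatter). The oxygen-linked group stands level with the other two groups on that carbon, with a 1.6-fold higher number from compound 2 to compound 4 (0.21 log units; within the scatter) and a 1.4-fold lower number from compound 1 to compound 4 (0.16 log units; within the scatter), although the number for compound 2 remains lower than that for compound 1 by more than the scatter. Compound 3 now lies beyond the scatter from all three other compounds, so this position accepts an oxygen link, an amino link and a carbon link alike, with the number remaining in the same region in compound 1, compound 2 and compound 4.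

The data shown offer no explanation for these differences. Compound 4 changes both the link and the hydroxy group at once, so a plain cyclohexylamino group on the same carbonyl carbon would be needed to tell these two changes apart.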